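Chloro Added to the Meta-Chloromethylbenzyl Purine Series

The source may hold more compounds than are shown below. What is called first, only, known or untested is meant among the compounds shown, and "the series" means these compounds.

Three compounds have numbers in a functional assay on SF-295 cells (Homo sapiens) for cytotoxicity, read by sulforhodamine B assay, with a stated time of 48 h; a higher number here means a weaker inhibitor of growth, a lower number a stronger inhibitor of growth. Compound 1 `ClCc1ccccc1Cn1cnc2c(Cl)nc(Cl)nc21` gives 3380 nM, compound 2 `ClCc1cccc(Cn2cnc3ncnc(Cl)c32)c1` gives 19100 nM and compound 3 `ClCc1cccc(Cn2cnc3c(Cl)nc(Cl)nc32)c1` gives 17000 nM. Compound 2 has the highest number of the three; compound 3 sits within the scatter of it, while compound 1 lies beyond the scatter below it.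

Compound 4 `ClCc1cccc(Cn2cnc3nc(Cl)nc(Cl)c32)c1` is not yet measured. It differs from compound 2 by chloro in place of hydrogen on an aromatic carbon, placed between two ring nitrogen atoms of the shared core. Going by the values given here, no measured pair shows this exact step. Since compound 3, which also carries two chloro groups, gives 17000 nM within the scatter of compound 2, no shift beyond the scatter is expected. Compound 4 is estimated at 16000 nM, range 6000 nM to 42000 nM, meaning an expected step of a 1.2-fold lower number from compound 2 to compound 4 (0.08 log units; within the scatter) in this assay.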

Compound 4, concentration for total growth inhibition: 3380 nM
For compound 4 the middle estimate is 4.7-fold (0.68 log units) above the measured one; the whole stated range lies above it.
By their numbers in this assay, from the lowest: compounds 1 and 4 (each within the scatter of the next); then compounds 3 and 2 (each within the scatter of the next).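

In this assay, going by these compounds alone, chloro in place of hydrogen on this aromatic carbon, between two ring nitrogen atoms, gives a 5.7-fold lower number from compound 2 to compound 4 (0.75 log units; beyond the scatter) and is the first single-place step. Within the data shown here, the earlier compounds offered no such pair, so this is the first sign that this position on the shared core responds to substitution. Nothing available explains the size of the step. As far as these compounds go, whether an amine or a methoxy group at this position gives a similar step remains open, as does whether the step holds in other cell lines.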